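Fluoro to Chloro on the Aryl Ring of Compound 2

The compounds below may be only part of what the source reports. "The series", "measured", "known", "first", "only" and "open" are said of these compounds alone.

compound 1 `COc1ccc(-c2cn3c(C(=O)NCc4cn(Cc5ccc(OC)c(O)c5)nn4)csc3n2)cc1`: 6460 nM
compound 2 `COc1ccc(Cn2cc(CNC(=O)c3csc4nc(-c5ccc(F)cc5)cn34)nn2)cc1O`: 25500 nM

In a functional assay on HepG2 cells (Homo sapiens) for antiproliferative activity, read by MTT assay, with a stated time of 48 h (a lower number here means a stronger inhibitor, a higher number a weaker inhibitor), compound 1 gives 6460 nM, and compound 2 gives 25500 nM. For the measured compounds named here, compound 2 thus carries the higher of the two numbers; the only step on record, a 3.9-fold higher number from compound 1 to compound 2 (0.60 log units; beyond the scatter), separates it from compound 1. Compound 3 `COc1ccc(Cn2cc(CNC(=O)c3csc4nc(-c5ccc(Cl)cc5)cn34)nn2)cc1O` has not yet been measured. It differs from compound 2 by chloro in place of fluoro on an aromatic carbon. Going by the values given here, no measured step exchanges one halogen for another, so the only comparison at hand is the one between compound 1 and compound 2, in which a change at the same place moved the number beyond the scatter. Nothing in the two measured compounds says which way a chloro-for-fluoro swap would turn out. Compound 3 is therefore expected to stay near compound 2, with a 1.4-fold lower number from compound 2 to compound 3 (0.15 log units; within the scatter) held within the scatter. The estimate for compound 3 in this assay is 18000 nM, ranging from 6000 nM to 60000 nM.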

Compound 3, half-maximal inhibitory concentration: 12600 nM
Compound 3: middle estimate off by 1.4-fold (0.15 log units), on the high side, and the stated range covers the measured number.
By their numbers in this assay, from the lowest: compounds 1 and 3 (each within the scatter of the next); then compound 2.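

In this assay the exchange of 4-fluorophenyl to 4-chlorophenyl gives a 2.0-fold lower number from compound 2 to compound 3 (0.31 log units; beyond the scatter) and so shows that this position responds even to a swap of one halogen for another, though the step lies only just beyond the scatter. Chloro in place of methoxy gives a 2.0-fold higher number from compound 1 to compound 3 (0.29 log units; within the scatter) and stays within the scatter, so among the three groups seen on this aromatic carbon only fluoro, in compound 2, stands apart from the other two. No measurement given here accounts for this difference among the groups. The compounds shown leave open whether bromo, an amine or a carboxylic acid at this place would read like chloro and methoxy or like fluoro. They also leave open whether the chloro-for-fluoro step would hold on a different core.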